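The source may hold more compounds than are shown below. What is called first, only, known or untested is meant among the compounds shown, and "the series" means these compounds.

Three compounds have been measured:

Compound 1 `CCC(=O)c1ccc(N(C)C(=O)CSc2nnc(CNc3ccccc3)n2CC)cc1` gives 580 nM in an assay on isolated protein for inhibition of long-chain fatty acid transport protein 1 (Homo sapiens); on this read-out lower numbers stand for stronger inhibition and higher numbers for weaker inhibition.
Compound 2 `CCn1c(CNc2ccccc2)nnc1SCc1nc2cc(F)ccc2o1` gives only a limit in this assay, namely > 1000 nM.
Compound 3 `CCOC(=O)c1ccc(NC(=O)CSc2nnc(CNc3ccccc3)n2CC)cc1` gives 330 nM in this assay.

Compound 1 and compound 3 share a core and each has a number. Among the compounds with values here, compound 2 stands apart: it is the one compound that sits at the limit of > 1000 nM in this assay, at which 1 of the 3 values shown sits, so only a limit and no number is known for it, and its standing relative to compound 1 and compound 3 cannot be put into figures.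

Compound 4 `CCn1c(CNc2ccccc2)nnc1SCc1nc2cc(OC(F)(F)F)ccc2o1` is not yet measured. It is built from compound 2 by one change: trifluoromethoxy in place of fluoro on an aromatic carbon. Within the data shown here, since no measured pair shows this change, the size of its effect in this assay has no measured precedent in this set, and no property of the entering group is known from these data.

The step from compound 2 to compound 4 is expected to be about a step that the limit leaves unreadable from compound 2 to compound 4, and a limit again is quite possible. Compound 4 is therefore estimated at 1500 nM, within a range from 400 nM to 6000 nM.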

Compound 4, half-maximal inhibitory concentration: 100 nM
Estimate against measurement, compound 4: 15-fold (1.18 log units) above; the whole stated range lies above it.
By their numbers in this assay, from the lowest: compound 4; then compounds 3 and 1 (each within the scatter of the next). At a limit, above all of these: compound 2.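

In this assay, trifluoromethoxy in place of fluoro on this aromatic carbon gives an at least 10-fold lower number from compound 2 to compound 4 (1.00 log units; beyond the scatter). Within the data shown here, this pair is the first sign that the group at this position, on the six-membered aromatic ring of the fused system, matters: one change is enough to bring the compound from a limit to a measured number. The true size of the step stays unknown because compound 2 has only a limit and no number: the limit of > 1000 nM in this assay, at which 1 of the 4 values shown sits.

A single pair cannot say whether this gain is particular to trifluoromethoxy, or whether methoxy, trifluoromethyl or chloro at the same carbon would do as well. It also leaves open where the compound with plain hydrogen at this carbon would fall relative to compound 2 and compound 4.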